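Larger Substituent on a Naphthalene-Bearing Sulfonamide

The source may hold more compounds than are shown below. What is called first, only, known or untested is meant among the compounds shown, and "the series" means these compounds.

Of the compounds shown here, three that share a sulfonamide-linked core have been tested in an assay on VSM-A10 cells for antagonist activity at Endothelin-1 receptor (Rattus norvegicus); a lower number here means a stronger inhibitor, a higher number a weaker inhibitor. Compound 1 `Cc1noc(NS(=O)(=O)c2cccc3c(CN(C)C)cccc23)c1C` gives 2800 nM in this assay. Compound 2 `Cc1noc(NS(=O)(=O)c2cccc(-c3ccccc3)c2)c1C` gives 5400 nM, and compound 3 `Cc1noc(NS(=O)(=O)c2ccc(F)cc2)c1C` gives 1000 nM. Compound 1 therefore stands second highest of the three numbers; its value and that of compound 2 lie within the scatter of each other, so no order can be read between them, whereas the gap from compound 1 down to compound 3 lies beyond the scatter.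

Compound 4 `Cc1noc(NS(=O)(=O)c2cccc3c(N/C(S)=N/c4ccccc4)cccc23)c1C` has not been measured. It differs from compound 1 in one place: a group of 10 heavy atoms (7 carbon, 2 nitrogen, 1 sulfur; one six-membered aromatic ring of carbon only) in place of a group of 4 heavy atoms (3 carbon, 1 nitrogen; no ring), on an aromatic carbon. The group that enters is much larger than the one that leaves and brings a ring of its own, while the shared core stays unchanged.

Going by the values given here, no measured pair in this set isolates a change of this kind, so the expected step is uncertain. Given that the two compounds with larger aromatic substituents, compound 1 and compound 2, sit no lower than the smallest one, compound 3, the expectation is a step from compound 1 to compound 4 of a 1.1-fold lower number from compound 1 to compound 4 (0.05 log units; within the scatter), that is, no change beyond the scatter. Compound 4 is estimated to give 2500 nM in this assay, with a likely range from 600 nM to 10000 nM.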

Compound 4, half-maximal inhibitory concentration: 150 nM
Estimate against measurement, compound 4: 17-fold (1.22 log units) above; the whole stated range lies above it.
By their numbers in this assay, from the lowest: compound 4; then compound 3; then compounds 1 and 2 (each within the scatter of the next).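

Going by these compounds alone, this is the first step in the set that isolates a single change, and it shows that the aromatic carbon carrying the (dimethylamino)methyl group in compound 1 is sensitive to what sits on it: in this assay, putting the much larger ring-bearing group there gives a 19-fold lower number from compound 1 to compound 4 (1.27 log units; beyond the scatter) and so moves the number well beyond the scatter. The position therefore tolerates a far bigger group, one that brings its own six-membered aromatic ring, a sulfur and hydrogen-bond donors that the group leaving does not have, and the number falls rather than rises. Nothing available explains why this single change has so large an effect.

What the compounds shown leave open is which part of the entering group carries the step: the sulfur, the six-membered aromatic ring or the nitrogens. A version with oxygen in place of the sulfur, or a plain amine or a carboxylic acid at this position, would begin to separate these parts, as would the same group on another aromatic carbon of the shared core.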